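Compound 1 to compound 4: a side chain removed

The source may hold more compounds than are shown below. What is called first, only, known or untested is meant among the compounds shown, and "the series" means these compounds.

Compound 1 `O=C(CN1CCCCC1)Nc1ccc(-c2nc3cc(Cl)c(Cl)cc3[nH]2)cc1` was tested in an ADME assay on BHK cells (Mesocricetus auratus) for cytotoxicity, read by MTT assay, with a stated time of 96 h (on this read-out lower numbers stand for higher toxicity in this test and higher numbers for lower toxicity in this test), and gave 39000 nM, the highest of the two numbers recorded there. Compound 2 `O=C(CN1CCCC1)Nc1ccc(-c2nc3cc(C(F)(F)F)ccc3[nH]2)cc1` gave 29000 nM in this assay, which lies within the scatter of the value for compound 1, so the two cannot be told apart. For compound 3 `Cn1c(-c2ccc([N+](=O)[O-])cc2)nc2cc(C(F)(F)F)ccc21` the result in this assay is > 100000 nM, which is the limit of > 100000 nM in this assay, at which 1 of the 3 values shown sits, and so a limit of the assay rather than a number. Compound 4 `Nc1ccc(-c2nc3cc(Cl)c(Cl)cc3[nH]2)cc1` has not yet been measured in this assay. It differs from compound 1 in one place: hydrogen in place of ((piperidin-1-yl)methyl)carbonyl on a nitrogen on an aromatic ring. Among the measured compounds shown here, no measured pair in this set shows the same change, so its effect can only be anticipated. For compound 4 one expects a step from compound 1 of modest size in this assay, if anything toward a higher number, and not clearly beyond the scatter, namely a 1.5-fold higher number from compound 1 to compound 4 (0.19 log units; within the scatter). For compound 4 the estimate in this assay is 60000 nM, within a range from 20000 nM to 150000 nM.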

Compound 4, half-maximal cytotoxic concentration: 30000 nM
Compound 4: middle estimate off by 2.0-fold (0.30 log units), on the high side; measured number inside the range.
By their numbers in this assay, from the lowest: compounds 2, 4 and 1 (each within the scatter of the next). At a limit, above all of these: compound 3.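

Replacing ((piperidin-1-yl)methyl)carbonyl with hydrogen on a nitrogen on an aromatic ring gives a 1.3-fold lower number from compound 1 to compound 4 (0.11 log units; within the scatter) in this assay. Among the compounds shown here, this is the first single-place comparison in the set, and it shows that, on the core of compound 1, the whole side chain, including its six-membered non-aromatic ring and carbonyl, can be removed without a difference that can be told from the scatter. Nothing measured among these compounds points to a cause for this result.

From the compounds shown here alone, this rests on a single pair, so it remains open whether the same holds with trifluoromethyl on the core in place of the two chlorines. Also open, going by these compounds, is how a simple acetyl group, a longer chain ending in an amine, or a carboxylic acid on this nitrogen would read in this assay.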